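The compounds below may be only part of what the source reports. "The series", "measured", "known", "first", "only" and "open" are said of these compounds alone.

Measured so far:
- compound 1, `C[C@H](CN1CCC(F)CC1)NC(=O)c1ccc(-c2noc(C(F)(F)F)n2)cc1`: 100 nM
- compound 2, `CC(C)(CN1CCCC1)NC(=O)c1ccc(-c2noc(C(F)(F)F)n2)cc1`: 310 nM

In an assay on Jurkat E6.1 cells for inhibition of histone deacetylase 4 (Homo sapiens), read by fluorescence (on this read-out lower numbers stand for stronger inhibition and higher numbers for weaker inhibition), compound 1 gives 100 nM and stands lowest of the two numbers. Compound 2 gives 310 nM in this assay, a higher number, and the gap between the two lies beyond the scatter; compound 2 differs from compound 1 in more than one place, so no single step can be read from the pair.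

Compound 3, `C[C@H](CN1CCCC(C)(C)C1)NC(=O)c1ccc(-c2noc(C(F)(F)F)n2)cc1`, has not yet been measured in this assay. It keeps the shared core of compound 1 and changes one group: 3,3-dimethylpiperidin-1-yl in place of 4-fluoropiperidin-1-yl on a saturated chain carbon, two bonds along the chain from an amide-type nitrogen. Without a measured step of this kind in the series, the direction is open. A modest step is expected, most likely toward a somewhat higher number, but the sizes are such that the result may also fall within the scatter of compound 1.

For compound 3 the expected step is a 1.6-fold higher number from compound 1 to compound 3 (0.20 log units; within the scatter), so compound 3 is estimated at 160 nM in this assay, with a range from 50 nM to 500 nM.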

Compound 3, half-maximal inhibitory concentration: 10 nM
Beside the measured number, compound 3's estimate is 16-fold (1.20 log units) above it; measured number below the stated range.
By their numbers in this assay, from the lowest: compound 3; then compound 1; then compound 2.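

In this assay, for the compounds shown here, the group on the saturated chain carbon, two bonds along the chain from an amide-type nitrogen, proves a sensitive place: 3,3-dimethylpiperidin-1-yl in place of 4-fluoropiperidin-1-yl gives a 10-fold lower number from compound 1 to compound 3 (1.00 log units; beyond the scatter) and this is the only single-place step so far. The two groups share one six-membered non-aromatic ring, the same donor and acceptor counts and no net charge, so those counted features do not separate compound 1 from compound 3. Nothing measured here accounts for the size of the step.

Going by these compounds, it remains open whether the lower number follows from losing the fluorine or from gaining the two methyl groups; unsubstituted piperidin-1-yl and 3-methylpiperidin-1-yl would separate these. On these data alone, whether 3,3-dimethylpiperidin-1-yl gives a similar step on the chain of compound 2 also stays open.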